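A few compounds are considered here, and "the series" means these few. Any claim that something is new, unique, unknown or untested is made for them only; others in the source may bear on it.

In a functional assay on cells (Hepatocyte, Rattus norvegicus) for inhibition, read by scintillation counting, with a stated time of 4 h (on this read-out higher numbers stand for weaker inhibition and lower numbers for stronger inhibition), three compounds sharing one core have been measured. Compound 1 (`Cc1ccccc1CNC(=O)c1nc(-c2ccc(F)cc2)n(CC[C@@H](O)C[C@@H](O)CC(=O)O)c1C1CC1`) gives 0.1 nM, compound 2 (`Cc1ccc(CNC(=O)c2nc(-c3ccc(F)cc3)n(CC[C@@H](O)C[C@@H](O)CC(=O)O)c2C2CC2)cc1`) gives 0.1 nM, and compound 3 (`COc1ccc(CNC(=O)c2nc(-c3ccc(F)cc3)n(CC[C@@H](O)C[C@@H](O)CC(=O)O)c2C2CC2)cc1`) gives 0.2 nM. The value of compound 3 thus lies within the scatter of both of the others, so the three cannot be ranked on these numbers.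

The next compound, compound 4 (`COc1ccccc1CNC(=O)c1nc(-c2ccc(F)cc2)n(CC[C@@H](O)C[C@@H](O)CC(=O)O)c1C1CC1`), differs from compound 3 in a single group: 2-methoxyphenyl in place of 4-methoxyphenyl on a saturated chain carbon bound to an amide-type nitrogen. Here, 2-methoxyphenyl stands in place of 4-methoxyphenyl on a saturated chain carbon bound to an amide-type nitrogen, and the two compounds have the same atoms, joined differently.

For the measured compounds named here, no measured step makes exactly this change. The nearest is the exchange of 2-methylphenyl for 4-methylphenyl, which shows no change at the digits printed from compound 1 to compound 2 (within the scatter). Two further steps involve methoxy: methoxy in place of methyl shows a 2.0-fold higher number from compound 2 to compound 3 (0.30 log units; within the scatter), and 4-methoxyphenyl in place of 2-methylphenyl shows a 2.0-fold higher number from compound 1 to compound 3 (0.30 log units; within the scatter). All three steps stay within the scatter, so no change beyond it is expected in this assay, although three small steps are thin evidence. The expected size is a 1.3-fold lower number from compound 3 to compound 4 (0.12 log units; within the scatter), which would not be a real difference. The estimate for compound 4 is 0.15 nM, with an expected range of 0.06 nM to 0.4 nM.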

Compound 4, half-maximal inhibitory concentration: 0.1 nM
Beside the measured number, compound 4's estimate is 1.5-fold (0.18 log units) above it, within the range that was stated.
By their numbers in this assay, from the lowest: compounds 1, 2, 4 and 3 (each within the scatter of the next).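

In this assay, 2-methoxyphenyl in place of 4-methoxyphenyl gives a 2.0-fold lower number from compound 3 to compound 4 (0.30 log units; within the scatter), so the methoxy pair now shows what the methyl pair had shown: the two placements of the group on the phenyl ring cannot be told apart at this position. The comparisons with the methyl compounds point the same way, with no change at the digits printed from compound 2 to compound 4 (within the scatter) and no change at the digits printed from compound 1 to compound 4 (within the scatter), so 2-methoxyphenyl cannot be separated from either 2-methylphenyl or 4-methylphenyl. The exchange of methyl for methoxy can now also be read in two settings, and it stays within the scatter in both: the same change on two cores in this assay, a 2.0-fold higher number (0.30 log units; within the scatter) from compound 2 to compound 3 and no change at the digits printed (within the scatter) from compound 1 to compound 4, 2.0-fold (0.30 log units) apart, within the scatter of two such steps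

The compounds shown carry only methyl and methoxy on this phenyl ring, so they leave open whether a carboxylic acid, an aminomethyl group or a longer chain such as butoxy in the same place would stay within the scatter as well. They also leave open whether this flat picture would hold if the rest of the shared core were altered, since all four compounds keep it unchanged.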